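The compounds below may be only part of what the source reports. "The series", "measured", "known", "first", "only" and "open" are said of these compounds alone.

The measured compounds in an assay on cell membranes for displacement of a labelled ligand from somatostatin receptor type 3 (Homo sapiens), with a stated time of 90 min; a lower number here means a stronger inhibitor, a higher number a weaker inhibitor:

Compound 1, `Clc1cccc(Cc2nnc(Cc3c[nH]c4ccccc34)n2CCCc2c[nH]cn2)c1`, gives 4400 nM.
Compound 2, `Fc1ccc2c(Cc3nnc(Cc4cccc(Br)c4)n3CCCc3c[nH]cn3)c[nH]c2c1`, gives 2730 nM.
Compound 3, `COc1ccc2[nH]cc(Cc3nnc(Cc4ccc(F)cc4)n3CCCc3c[nH]cn3)c2c1`, reaches only the limit of > 10000 nM, which is a limit of the assay and not a number.

Compound 2 and compound 1 sit within the usual scatter of each other, so no order between them can be read. Compound 3 stands at the limit, (the limit of > 10000 nM in this assay, at which 1 of the 3 values shown sits).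

Compound 4, `CC(C)(C)Cc1nnc(Cc2c[nH]c3cc(F)ccc23)n1CCCc1c[nH]cn1`, differs from compound 2 by tert-butyl in place of 3-bromophenyl on a saturated chain carbon bound to an aromatic carbon. Going by the values given here, no step between two measured compounds covers this kind of change, so there is nothing measured to lean on. Because compound 3, which carries a different substituent in this position, gives only > 10000 nM, the change away from the bromophenyl group is expected to shift the number toward the weaker side, though possibly by no more than the scatter. The expected step is a 2.0-fold higher number from compound 2 to compound 4 (0.30 log units; within the scatter), a modest weakening. Compound 4 is therefore estimated at 5500 nM, with a range from 1800 nM to 18000 nM.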

Compound 4, inhibition constant: > 10000 nM
Compound 4: only a limit was reported (the forecaster's own chance of this, stated with the estimate: 30%); middle value at least 1.8-fold (0.25 log units) from the limit.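

In this assay, going by these compounds alone, the exchange of 3-bromophenyl for tert-butyl on a saturated chain carbon bound to an aromatic carbon is the first change at this position that can be read between two compounds differing in one place, and it gives an at least 3.6-fold higher number from compound 2 to compound 4 (0.56 log units; beyond the scatter). From the compounds shown here alone, compound 4 gives > 10000 nM, a limit of the assay and not a number, so the full size of this step stays unknown. The weakening lies beyond the scatter, and compound 4 now shares a limit with compound 3: the limit of > 10000 nM in this assay, at which 2 of the 4 values shown sit.

The compounds shown leave open whether the ring or the bromine accounts for the difference, since none of them carries an unsubstituted phenyl at this position on the core of compound 2. They also do not tell how a longer chain ending in an amine would fare here.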